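Working notes on compound 3 before measurement

This account rests on a few compounds, and the source may have more. Where it says the series, first, only, none or still open, it means among the compounds named here.

For the measured compounds named here, the series shares one core, seen in compound 1 `Cc1ccc(-n2nccn2)c(C(=O)N2C[C@H](C#Cc3cccnc3)CC[C@H]2C)c1`, which in an assay on cells for binding affinity to Orexin receptor type 2 (Homo sapiens), read by radioligand binding (on this read-out higher numbers stand for weaker inhibition and lower numbers for stronger inhibition), gives 41 nM, the lowest of the two numbers so far. Compound 2 `Cc1ccc(-n2nccn2)c(C(=O)N2C[C@H](C#Cc3ccc(CO)nc3)CC[C@H]2C)c1` carries hydroxymethyl on an aromatic carbon and in this assay gives 150 nM; the step of a 3.7-fold higher number from compound 1 to compound 2 (0.56 log units; beyond the scatter) is modest but beyond the scatter.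

Compound 3 `Cc1ccc(-n2nccn2)c(C(=O)N2C[C@H](C#Cc3ccc(F)cn3)CC[C@H]2C)c1` differs from compound 1 as follows: 5-fluoropyridin-2-yl in place of pyridin-3-yl on a triple-bonded carbon. The pyridin-3-yl leaves and 5-fluoropyridin-2-yl enters, on a triple-bonded carbon whose other neighbour is a triple-bonded carbon; cut one bond further out, 2-(pyridin-3-yl)ethynyl becomes 2-(5-fluoropyridin-2-yl)ethynyl.

Going by the values given here, no measured step covers this exchange. Among the compounds with values here, the single step of a 3.7-fold higher number from compound 1 to compound 2 (0.56 log units; beyond the scatter) shows only that adding hydroxymethyl to the ring weakens binding modestly; it says nothing about exchanging the ring itself or bringing in fluorine. Without a direct precedent, the expectation for compound 3 is a step of roughly a 1.6-fold higher number from compound 1 to compound 3 (0.20 log units; within the scatter) in this assay, within or just beyond the scatter, towards a higher number. Compound 3 is therefore estimated at 65 nM, with a range from 20 nM to 220 nM.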

Compound 3, inhibition constant: 1.1 nM
Estimate against measurement, compound 3: 59-fold (1.77 log units) above; the measured number lies below the stated range.
By their numbers in this assay, from the lowest: compound 3; then compound 1; then compound 2.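

In this assay, exchanging the whole aromatic group on the triple-bonded carbon has a much larger effect than the one substitution seen before: 5-fluoropyridin-2-yl in place of pyridin-3-yl gives a 37-fold lower number from compound 1 to compound 3 (1.57 log units; beyond the scatter), whereas hydroxymethyl on the ring gave only a 3.7-fold higher number from compound 1 to compound 2 (0.56 log units; beyond the scatter). Set against the hydroxymethyl compound, the same position gives a 140-fold lower number from compound 2 to compound 3 (2.13 log units; beyond the scatter), so this single site spans the whole range of the three compounds, with compound 3 the strongest binder of the set and both of its steps beyond the scatter. No measurement available here bears on the reason for this large gain.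

The step from compound 1 to compound 3 changes the point of attachment of the pyridine and adds fluorine in one exchange, and the compounds shown do not separate the two, since neither unsubstituted pyridin-2-yl nor 5-fluoropyridin-3-yl appears among them. Going by these compounds, it also remains open whether fluorine is the preferred substituent on the pyridin-2-yl group, or whether 5-chloropyridin-2-yl, 5-methoxypyridin-2-yl or 5-cyanopyridin-2-yl would hold a number as low as that of compound 3.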